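The compounds below may be only part of what the source reports. "The series", "measured", "known", "first", "only" and "open" are said of these compounds alone.

Compound 2 `Fc1cc(Cl)ccc1-c1ccc(Cn2nnc3ccccc32)cc1` stands lowest of the two numbers in an ADME assay on microsomes from liver (Mus musculus, strain NMRI) for metabolic stability, tested at 2.5 uM (on this read-out higher numbers stand for fast clearance and lower numbers for slow clearance), giving 1.1 mL/min/g. Compound 1 `Fc1ccc(-c2ccc(Cn3nnc4ccccc43)cc2)c(F)c1` gives 2.3 mL/min/g in this assay. Within the data shown here, the only measured step is a 2.1-fold lower number from compound 1 to compound 2 (0.32 log units; beyond the scatter), a modest change. Compound 3 `Fc1cc(C(F)(F)F)ccc1-c1ccc(Cn2nnc3ccccc32)cc1` differs from compound 2 by trifluoromethyl in place of chloro on an aromatic carbon. Among the measured compounds shown here, that step swaps one halogen for another and offers only a loose guide here, since no measured pair shows trifluoromethyl in place of chloro. A small change or none beyond the scatter is therefore expected for compound 3, estimated at 1 mL/min/g with a range of 0.5 mL/min/g to 2.1 mL/min/g, meaning an expected step of a 1.1-fold lower number from compound 2 to compound 3 (0.04 log units; within the scatter).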

Compound 3, intrinsic clearance in a liver preparation (reported as CLH), per the amount of preparation that the assay uses: 1.2 mL/min/g
The estimate for compound 3 lay 1.2-fold (0.08 log units) below the measured number; the measured number falls inside the stated range.
By their numbers in this assay, from the lowest: compounds 2, 3 and 1 (each within the scatter of the next, the first and the last beyond it).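

In this assay, trifluoromethyl in place of chloro at this position gives a 1.1-fold higher number from compound 2 to compound 3 (0.04 log units; within the scatter), so a group of 4 heavy atoms and a group of 1 heavy atom cannot be told apart here. Set against fluoro, trifluoromethyl gives a 1.9-fold lower number from compound 1 to compound 3 (0.28 log units; within the scatter), so it does not stand clearly apart from fluoro, although chloro does. No measurement shown offers a reason for these numbers.

Still open, on these data alone, is how a different kind of group at this position, such as an amine, a carboxylic acid or a methoxy group, would compare. Also open, as far as these compounds go, is whether these steps would hold elsewhere on the shared core.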